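Moving a hydroxyphenyl onto a second sulfonate core

The source may report more compounds than this note shows. Statements on the series, on what has been measured and on what is new or still open speak of the compounds shown alone.

The measure here is a functional assay on HT-29 cells (Homo sapiens) for cytotoxicity, read by sulforhodamine B assay, with a stated time of 48 h; on this read-out lower numbers stand for stronger inhibition and higher numbers for weaker inhibition. Compound 1 `CCCc1ccccc1OS(=O)(=O)c1cccc(NC(=O)NCCCCl)c1` gives 14000 nM in this assay. Compound 2 `O=C(NCCCCl)Nc1cccc(S(=O)(=O)Oc2ccc(O)cc2)c1` differs from compound 1 by a single change, (4-hydroxyphenyl in place of 2-propylphenyl on an oxygen), and in this assay compound 2 gives 51000 nM. Going by the values given here, the change produced a 3.6-fold higher number from compound 1 to compound 2 (0.56 log units; beyond the scatter), so the compound carrying the 4-hydroxyphenyl group on the oxygen came out as a weaker inhibitor than the one carrying the 2-propylphenyl group.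

Compound 3 `CCCc1ccccc1OS(=O)(=O)c1ccc(NC(=O)NCCCCl)cc1` is built from the same atoms as compound 1, joined differently; the difference between the two cores is not broken down here. In this assay compound 3 gives 13000 nM, which sits within the scatter of the number for compound 1.

Compound 4 `O=C(NCCCCl)Nc1ccc(S(=O)(=O)Oc2ccc(O)cc2)cc1` has not yet been measured. It differs from compound 3 by 4-hydroxyphenyl in place of 2-propylphenyl on an oxygen, the same change, at the same kind of place, that separates compound 2 from compound 1. Since compound 3 and compound 1 give numbers within the scatter of each other, the step is expected to repeat on the new core: the estimated step is a 3.6-fold higher number from compound 3 to compound 4 (0.56 log units; beyond the scatter), because the earlier change gave a 3.6-fold higher number from compound 1 to compound 2 (0.56 log units; beyond the scatter). Compound 4 is therefore expected to give about 47000 nM in this assay, with a likely range from 24000 nM to 95000 nM.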

Compound 4, half-maximal inhibitory concentration: 50000 nM
Compound 4: middle estimate off by 1.1-fold (0.03 log units), on the low side, within the range that was stated.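

On the core of compound 3, putting 4-hydroxyphenyl in place of 2-propylphenyl on the oxygen gave a 3.8-fold higher number from compound 3 to compound 4 (0.59 log units; beyond the scatter) in this assay, so compound 4 is again the weaker inhibitor of its pair. Set side by side, the two steps agree in size, and in this small series the change carries from one core to the other: the same change on two cores in this assay, a 3.6-fold higher number (0.56 log units; beyond the scatter) from compound 1 to compound 2 and a 3.8-fold higher number (0.59 log units; beyond the scatter) from compound 3 to compound 4, 1.1-fold (0.02 log units) apart, within the scatter of two such steps. Going by these compounds alone, this agreement rests on only two pairs of compounds in a single cell assay, so it does not show that the step would hold on any further core, and it does not explain why the number rises, since the 2-propylphenyl group leaves and the 4-hydroxyphenyl group enters in one move.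

The compounds shown leave open how much of the step belongs to losing the propyl chain and how much to gaining the hydroxyl group, a question that a plain phenyl or a 4-methoxyphenyl group on the same oxygen could help to separate. They also leave open whether the step would persist if the chain ending in chlorine were replaced by a longer chain or by one ending in an amine.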